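The source may hold more compounds than are shown below. What is called first, only, known or untested is meant among the compounds shown, and "the series" means these compounds.

Measured in a functional assay on HeLa cells (Homo sapiens) for antiproliferative activity, read by MTT assay, with a stated time of 48 h; on this read-out higher numbers stand for weaker inhibition and lower numbers for stronger inhibition:

- compound 1 `Fc1ccc2[nH]c(-c3cn(-c4ccccc4)nc3-c3ccccc3)nc2c1`: 3610 nM
- compound 2 `Clc1ccc2[nH]c(-c3cn(-c4ccccc4)nc3-c3ccccc3)nc2c1`: 3480 nM
- compound 3 `Fc1ccc(-c2nn(-c3ccccc3)cc2-c2nc3cc(F)ccc3[nH]2)cc1`: 1570 nM

Compound 3 gives the lowest number of the three, with compound 2 and compound 1 both higher by more than the scatter. The two cores differ by fluoro in place of hydrogen on an aromatic carbon, and that change made a 2.3-fold lower number from compound 1 to compound 3 (0.36 log units; beyond the scatter). The change chloro in place of fluoro on an aromatic carbon made a 1.0-fold lower number from compound 1 to compound 2 (0.02 log units; within the scatter).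

Compound 4 `Fc1ccc(-c2nn(-c3ccccc3)cc2-c2nc3cc(Cl)ccc3[nH]2)cc1` has not yet been measured in this assay. Within the data shown here, it differs from compound 3 by chloro in place of fluoro on an aromatic carbon, the same change, at the same place, as the one from compound 1 to compound 2. The step from compound 3 to compound 4 is expected to be a 1.0-fold lower number from compound 3 to compound 4 (0.01 log units; within the scatter) because the matching step gave a 1.0-fold lower number from compound 1 to compound 2 (0.02 log units; within the scatter). Compound 4 is therefore estimated at 1550 nM, expected to fall between 750 nM and 3300 nM.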

Compound 4, half-maximal inhibitory concentration: 2770 nM
Estimate against measurement, compound 4: 1.8-fold (0.25 log units) below; measured number inside the range.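

In this assay, chloro in place of fluoro on an aromatic carbon gives a 1.8-fold higher number from compound 3 to compound 4 (0.25 log units; within the scatter), and this step cannot be told apart from its match on the other core: the same change on two cores in this assay, a 1.0-fold lower number (0.02 log units; within the scatter) from compound 1 to compound 2 and a 1.8-fold higher number (0.25 log units; within the scatter) from compound 3 to compound 4, 1.8-fold (0.26 log units) apart, within the scatter of two such steps. Fluoro in place of hydrogen on an aromatic carbon gives a 1.3-fold lower number from compound 2 to compound 4 (0.10 log units; within the scatter), and this step likewise cannot be told apart from its earlier match: the same change on two cores in this assay, a 2.3-fold lower number (0.36 log units; beyond the scatter) from compound 1 to compound 3 and a 1.3-fold lower number (0.10 log units; within the scatter) from compound 2 to compound 4, 1.8-fold (0.26 log units) apart, within the scatter of two such steps. Both changes therefore carry between these two cores within the scatter, but this rests on a single pair of cores, and the fluoro step passes the scatter on only one of them, so no dependable gain from it is shown.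

The compounds shown leave open whether the agreement extends beyond halogens. An amine, a methoxy group or a carboxylic acid on the same aromatic carbon remains to be compared.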